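Three Triazoles with High Cytotoxicity and a Methoxy Analogue

This account rests on a few compounds, and the source may have more. Where it says the series, first, only, none or still open, it means among the compounds named here.

Measured compounds:
- compound 1 `Oc1cc(C(F)(F)F)ccc1-c1nc(-c2ccccc2O)n(-c2ccc(I)cc2)n1`: 94.4%
- compound 2 `Oc1cc(C(F)(F)F)ccc1-c1nc(-c2ccccc2O)n(-c2ccc(C(F)(F)F)cc2)n1`: 90.5%
- compound 3 `Oc1cc(C(F)(F)F)ccc1-c1nc(-c2ccccc2O)n(-c2ccccc2Cl)n1`: 90.6%

In a functional assay on PC-12 cells (Rattus norvegicus) for cytotoxicity, read by MTT assay, with stated times of 2 h and 24 h, tested at 5 uM (a higher number here means a stronger effect of the compound at the concentration tested, a lower number a weaker effect), compound 1 gives 94.4%, the highest of the three numbers, though its steps to the other two are within the scatter: a number 3.9 percentage points lower from compound 1 to compound 2 (within the scatter) and a number 3.8 percentage points lower from compound 1 to compound 3 (within the scatter). The step of a number 0.1 percentage points higher from compound 2 to compound 3 (within the scatter) is likewise within the scatter, so the three compounds cannot be ordered on these numbers.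

Compound 4 `COc1cccc(-n2nc(-c3ccc(C(F)(F)F)cc3O)nc2-c2ccccc2O)c1` is not yet measured. It differs from compound 1 as follows: 3-methoxyphenyl in place of 4-iodophenyl on an aromatic nitrogen. Among the measured compounds shown here, the steps that bear on this change are those that swap the group on the aromatic nitrogen, a number 3.8 percentage points lower from compound 1 to compound 3 (within the scatter) and a number 0.1 percentage points higher from compound 2 to compound 3 (within the scatter), both within the scatter. Changing the ring on the aromatic nitrogen has therefore not produced a step beyond the scatter so far, and the same is expected here: the step of a number 4.4 percentage points lower from compound 1 to compound 4 (within the scatter) is expected to stay within the scatter. Compound 4 is thus estimated to give 90% in this assay, within a range from 76% to 98%.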

Compound 4, a percentage reported as activity, at one concentration (the size of the read-out at that concentration, not a potency): 96.8%
Compound 4: the middle estimate sits 6.8 percentage points below what was measured; low and high end bracket the measured number.
By their numbers in this assay, from the lowest: compounds 2, 3, 1 and 4 (each within the scatter of the next).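

In this assay, among the compounds shown here, the 3-methoxyphenyl group is the first ring on this aromatic nitrogen to carry oxygen and a hydrogen-bond acceptor, where the earlier rings carried iodo, trifluoromethyl or chloro. This change still gives only small steps: a number 2.4 percentage points higher from compound 1 to compound 4 (within the scatter) and a number 6.2 percentage points higher from compound 3 to compound 4 (within the scatter) and also a number 6.3 percentage points higher from compound 2 to compound 4 (within the scatter) so the wider range of rings at this position has not yet produced a step beyond the scatter. Nothing measured here accounts for these numbers.

The compounds shown leave open whether a ring bearing an amine or a carboxylic acid, or a longer chain in place of the ring, would move the number beyond the scatter. They also leave open what happens when the shared core keeps this ring but loses either hydroxyl group.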